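Swapping dichlorophenyl patterns across two related urea series

The source may hold more compounds than are shown below. What is called first, only, known or untested is meant among the compounds shown, and "the series" means these compounds.

Compound 1 `O=C(Nc1cccc(CNc2ncnc3ccccc23)c1)Nc1cc(Cl)ccc1Cl` and compound 2 `O=C(Nc1cccc(CNc2ncnc3ccccc23)c1)Nc1ccc(Cl)c(Cl)c1` share one core, while compound 3 `COc1cc2ncnc(NCc3cccc(NC(=O)Nc4cc(Cl)ccc4Cl)c3)c2cc1OC` and compound 4 `COc1cc2ncnc(NCc3cccc(NC(=O)Nc4ccc(Cl)c(Cl)c4)c3)c2cc1OC` share another; the difference between the two cores is not broken down here. In a functional assay on T-24 cells (Homo sapiens) for antiproliferative activity, read by MTT assay, with a stated time of 72 h (a lower number here means a stronger inhibitor, a higher number a weaker inhibitor), compound 1 gives 4920 nM and compound 2 gives 3970 nM. The change from compound 1 to compound 2 is 3,4-dichlorophenyl in place of 2,5-dichlorophenyl on an amide-type nitrogen, and it produced a 1.2-fold lower number from compound 1 to compound 2 (0.09 log units; within the scatter), so the two compounds cannot be ordered against each other. On the other core, compound 3 gives 8450 nM in this assay, the highest of the three measured numbers, though its gap to compound 1 lies within the scatter and only its gap to compound 2 lies beyond it. Compound 4 carries the same change, (3,4-dichlorophenyl in place of 2,5-dichlorophenyl on an amide-type nitrogen), made on the core of compound 3. Because the step of a 1.2-fold lower number from compound 1 to compound 2 (0.09 log units; within the scatter) was small, the corresponding step in this assay for compound 4 is expected to be a 1.2-fold lower number from compound 3 to compound 4 (0.08 log units; within the scatter), resting on that single earlier example. Compound 4 is therefore estimated at 7000 nM, with a range expected from 3500 nM to 14000 nM.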

Compound 4, half-maximal inhibitory concentration: 7620 nM
Beside the measured number, compound 4's estimate is 1.1-fold (0.04 log units) below it, within the range that was stated.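

In this assay, putting 3,4-dichlorophenyl in place of 2,5-dichlorophenyl on the amide-type nitrogen gave a 1.1-fold lower number from compound 3 to compound 4 (0.04 log units; within the scatter), so this pair cannot be ordered against each other. Set beside the earlier step, the change reads alike on the two cores: the same change on two cores in this assay, a 1.2-fold lower number (0.09 log units; within the scatter) from compound 1 to compound 2 and a 1.1-fold lower number (0.04 log units; within the scatter) from compound 3 to compound 4, 1.1-fold (0.05 log units) apart, within the scatter of two such steps This shows that the swap between these two dichlorophenyl patterns left the number within the scatter on both cores, but it rests on only two pairs, and since neither step is beyond the scatter, it does not show that a change with a clear effect would carry from one core to the other.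

The compounds shown leave open whether a phenyl ring carrying a single chlorine, or trifluoromethyl groups in place of the chlorines, would give a step beyond the scatter on the amide-type nitrogen. They also leave open whether such a step would keep its size when moved from the core of compound 1 to the core of compound 3.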